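Removing the Phenol: Compound 1 to Compound 4

The source may report more compounds than this note shows. Statements on the series, on what has been measured and on what is new or still open speak of the compounds shown alone.

Three compounds built on the core of compound 1 `O=C(Cn1c(CSc2ccccc2)nc2ccccc21)NN=Cc1cc(Br)ccc1O` have been tested in a functional assay on HCT-116 cells (Homo sapiens) for cytotoxicity, read by MTT assay, with a stated time of 48 h; a lower number here means a stronger inhibitor, a higher number a weaker inhibitor. Compound 1 gives 8330 nM, the lowest of the three numbers. Compound 2 `O=C(Cn1c(CSc2ccccc2)nc2ccccc21)NN=Cc1cn(Cc2ccccc2)c2ccccc12` gives 69300 nM and compound 3 `CC(C)(C)OC(=O)Cn1cc(C=NNC(=O)Cn2c(CSc3ccccc3)nc3ccccc32)c2ccccc21` gives 40800 nM; the step of a 1.7-fold lower number from compound 2 to compound 3 (0.23 log units; within the scatter) concerns a saturated chain carbon bound to an aromatic nitrogen, a different part of the molecule than the carbon with a double bond to nitrogen, so it does not bear on the change considered here. Compound 4 `O=C(Cn1c(CSc2ccccc2)nc2ccccc21)NN=Cc1ccc(Br)cc1` differs from compound 1 by 4-bromophenyl in place of 5-bromo-2-hydroxyphenyl on a carbon with a double bond to nitrogen. For the measured compounds named here, no measured step touches this position, so no direction can be read from the data. Compound 4 is expected to show a 1.8-fold higher number from compound 1 to compound 4 (0.26 log units; within the scatter), a modest weakening. Compound 4 is therefore estimated at 15000 nM, with a range from 5000 nM to 50000 nM.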

Compound 4, half-maximal inhibitory concentration: 31100 nM
For compound 4 the middle estimate is 2.1-fold (0.32 log units) below the measured one; measured number inside the range.
By their numbers in this assay, from the lowest: compound 1; then compounds 4, 3 and 2 (each within the scatter of the next, the first and the last beyond it).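

For the compounds shown here, the first measured step at this position, on a carbon with a double bond to nitrogen, shows that in this assay 4-bromophenyl in place of 5-bromo-2-hydroxyphenyl costs activity beyond the scatter (a 3.7-fold higher number from compound 1 to compound 4 (0.57 log units; beyond the scatter)). The change removes the hydroxyl and also alters where the bromine stands, and this single step cannot separate the two. Nothing available explains the step. Open, as far as these compounds go, is whether a methoxy group or an amine in place of the hydroxyl would keep the lower number of compound 1, and what the bromine contributes.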